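Hydroxy-bearing aryl groups in a pyrazoline series

This account rests on a few compounds, and the source may have more. Where it says the series, first, only, none or still open, it means among the compounds named here.

Of the compounds shown here, three have been measured in an assay on isolated protein for inhibition of protein kinase C zeta type (Homo sapiens), with a stated time of 4 min, tested at 62.5 uM; on this read-out higher numbers stand for more inhibition at the one concentration tested (going by the name of the read-out) and lower numbers for less inhibition. Compound 1 `Oc1ccc(C2CC(c3cccs3)=NN2c2ccc(C(F)(F)F)cc2)cc1` gives 99.4% in this assay. Compound 2 `CC(C)(C)C1=NN(c2ccc(Cl)cc2)C(c2ccc(Cl)cc2)C1` gives 11.8%, the lowest of the three numbers, and compound 3 `CC(C)(C)C1=NN(c2ccc(O)cc2)C(c2ccc(Cl)cc2)C1` gives 72.2%. Among the measured compounds shown here, the single measured step, a number 60.4 percentage points higher from compound 2 to compound 3 (beyond the scatter), shows that a hydroxy in place of a chloro on an aromatic carbon of the ring on the ring nitrogen lifts the read-out strongly.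

Compound 4 `CC(C)(C)C1=NN(c2ccc(Cl)cc2)C(c2ccc(O)c(Cl)c2)C1` is not yet measured. It differs from compound 2 in one place: 3-chloro-4-hydroxyphenyl in place of 4-chlorophenyl on a saturated ring carbon. For the measured compounds named here, no measured step covers a change on the ring on the saturated ring carbon, so the bearing of the existing data is indirect. Still, compound 1, which carries a hydroxyphenyl on that saturated carbon, gives 99.4%, and the step from compound 2 to compound 3 shows that adding a hydroxy to an aryl ring of this core is met by a large rise. A rise is therefore expected from compound 2 to compound 4, as a number 48.2 percentage points higher from compound 2 to compound 4 (beyond the scatter), though smaller and less certain because a number 60.4 percentage points higher from compound 2 to compound 3 (beyond the scatter) concerns the other ring. Compound 4 is estimated at 60%, within 30% to 90%.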

Compound 4, a percentage reported as inhibition, at one concentration (the size of the read-out at that concentration, not a potency): 94.5%
Estimate against measurement, compound 4: 34.5 percentage points below, and the stated range ends below it.
By their numbers in this assay, from the lowest: compound 2; then compound 3; then compounds 4 and 1 (each within the scatter of the next).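

On the saturated ring carbon, 3-chloro-4-hydroxyphenyl in place of 4-chlorophenyl gives, in this assay, a number 82.7 percentage points higher from compound 2 to compound 4 (beyond the scatter). The read-out therefore responds strongly to a change on this ring as well, not only to the change on the ring on the ring nitrogen in a number 60.4 percentage points higher from compound 2 to compound 3 (beyond the scatter), and a chlorine on this ring does not by itself keep the number low, since compound 4 still carries one. The compounds shown offer no measured basis for explaining this rise.

Going by these compounds, the share of the hydroxy and that of the chlorine in the rise remain open, as both differ within this single change. Also open, on these data alone, is whether an amine or a carboxylic acid in place of the hydroxy on this ring would keep the read-out high.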